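Swapping Pentyl for Benzyloxy on a Carbonyl Carbon

A few compounds are considered here, and "the series" means these few. Any claim that something is new, unique, unknown or untested is made for them only; others in the source may bear on it.

compound 1 `CCCCCCCCc1ccc(CCC(CO)(CO)NC(=O)CCCCC)c2ccccc12` gives 20300 nM
compound 2 `CCCCc1ccc(COc2ccc(CCC(CO)(CO)NC(C)=O)c3ccccc23)cc1` gives 27100 nM
compound 3 `CCCCCCCOc1ccc(CCC(CO)(CO)NC(=O)CCCCC)c2ccccc12` gives 21900 nM

All three values come from a functional assay on HT-29 cells (Homo sapiens) for antiproliferative activity, read by sulforhodamine B assay, with a stated time of 72 h (on this read-out higher numbers stand for weaker inhibition and lower numbers for stronger inhibition), and compound 3 lies within the scatter of both other compounds, so it holds no distinct place among them. Compound 4 `CCCCCCCOc1ccc(CCC(CO)(CO)NC(=O)OCc2ccccc2)c2ccccc12` awaits measurement and differs from compound 3 in one place (benzyloxy in place of pentyl on a carbonyl carbon) with benzyloxy in place of pentyl on a carbonyl carbon. Going by the values given here, the one measured step is a 1.1-fold higher number from compound 1 to compound 3 (0.03 log units; within the scatter) but it concerns heptyloxy in place of octyl, so it bears on this change only indirectly. Among the compounds with values here, no measured step tests benzyloxy here. Given these closely grouped values, no step beyond the scatter is expected in this assay for this change. The estimated step is a 1.1-fold lower number from compound 3 to compound 4 (0.04 log units; within the scatter) on this expectation. Compound 4 is estimated at 20000 nM with an expected range of 8000 nM to 45000 nM in this same test.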

Compound 4, half-maximal inhibitory concentration: 60500 nM
Compound 4: middle estimate off by 3.0-fold (0.48 log units), on the low side, outside the stated range (above it).
By their numbers in this assay, from the lowest: compounds 1, 3 and 2 (each within the scatter of the next); then compound 4.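

The group on this carbonyl carbon is not interchangeable in this assay: benzyloxy in place of pentyl gives a 2.8-fold higher number from compound 3 to compound 4 (0.44 log units; beyond the scatter) and is the only step shown that lies beyond the scatter. The heptyloxy and octyl compounds had not revealed this sensitivity, since that change sits elsewhere on the molecule. Nothing measured here explains the step.

Whether the aromatic ring or the added oxygen of benzyloxy accounts for it stays open. So does the outcome with an amine or a longer chain, such as decyl, on this carbonyl carbon.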